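The source may report more compounds than this note shows. Statements on the series, on what has been measured and on what is new or still open speak of the compounds shown alone.

Of the compounds shown here, three sharing one core have been measured in an assay on isolated protein for inhibition of MAP kinase-activated protein kinase 5 (Homo sapiens), read by mobility shift assay, tested at 30 uM; on this read-out lower numbers stand for less inhibition and higher numbers for more inhibition at the one concentration tested (going by the name of the read-out). Compound 1 `Cc1cc2nn(-c3ccccc3)c(N)c2c(=O)[nH]1` gives 5%, compound 2 `CC(C)(C)c1cc2nn(-c3ccccc3)c(N)c2c(=O)[nH]1` gives 2%, and compound 3 `Nc1c2c(=O)[nH]c(-c3ccccn3)cc2nn1-c1ccccc1` gives 2%. Compound 3 stands level with compound 2 and within the scatter of compound 1: the step of a number 3 percentage points lower from compound 1 to compound 3 (within the scatter) and the step of no change at the digits printed from compound 2 to compound 3 (within the scatter) both stay inside the scatter, as does a number 3 percentage points lower from compound 1 to compound 2 (within the scatter), so nothing separates the three.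

Compound 4 `COc1ccc(-c2cc3nn(-c4ccccc4)c(N)c3c(=O)[nH]2)cc1` differs from compound 3 at the same aromatic carbon: 4-methoxyphenyl in place of pyridin-2-yl on an aromatic carbon. Going by the values given here, the steps that bear on this position, from methyl to tert-butyl to pyridin-2-yl, all left this assay unmoved, so a further exchange there is expected to leave the read-out essentially where compound 3 sits, with no step beyond the scatter in either direction. Compound 4 is therefore expected to give 3% in this assay, within a range from -5% to 12%. The expected step of a number 1 percentage points higher from compound 3 to compound 4 (within the scatter) is estimated to lie inside the scatter.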

Compound 4, a percentage reported as inhibition, at one concentration (the size of the read-out at that concentration, not a potency): 12%
Compound 4: middle estimate off by 9 percentage points, on the low side, and the stated range covers the measured number.
By their numbers in this assay, from the lowest: compounds 2, 3, 1 and 4 (each within the scatter of the next).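

Swapping in 4-methoxyphenyl shows that a larger aryl group on this aromatic carbon, with a ring of carbon only in place of the pyridin-2-yl ring, still does not separate the compounds in this assay. The steps of a number 10 percentage points higher from compound 3 to compound 4 (within the scatter), a number 10 percentage points higher from compound 2 to compound 4 (within the scatter) and a number 7 percentage points higher from compound 1 to compound 4 (within the scatter) are the largest seen at this position, yet each is printed as within the scatter, so the four compounds remain indistinguishable on this read-out. No supporting data bear on this result.

On these data alone, it remains open whether a carboxylic acid or an aliphatic amine on this carbon would move the read-out beyond the scatter. Also open, as far as these compounds go, is whether plain phenyl would match 4-methoxyphenyl, which would show what the methoxy group contributes to the step.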